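A Methyl on the Ring Nitrogen of Compound 3

The compounds below may be only part of what the source reports. "The series", "measured", "known", "first", "only" and "open" are said of these compounds alone.

Three compounds of one shared core, each carrying a fluorophenyl group, have been tested in a functional assay on the whole organism (strain Holtzman) with Rattus norvegicus as the target; on this read-out lower numbers stand for an effect already at smaller amounts and higher numbers for an effect only at larger amounts of compound. Compound 1 `CCc1nn(C)c2c1C(c1ccccc1F)=NCC(=O)N2` gives 1.25 mg/kg; 1.25 mg/kg (2 entries) in this assay. Compound 2 `CCc1nn(C)c2c1C(c1cccc(F)c1)=NCC(=O)N2C` differs from compound 1 in more than one place; in this assay compound 2 gives 10 mg/kg. Compound 3 `CCc1nn(C)c2c1C(c1ccc(F)cc1)=NCC(=O)N2` is known only by a limit of the assay rather than a number: compound 3 gives > 40 mg/kg. Going by the values given here, compound 3 is the single value that stands at the limit of > 40 mg/kg in this assay, at which 1 of the 3 values shown sits.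

Compound 4 `CCc1nn(C)c2c1C(c1ccc(F)cc1)=NCC(=O)N2C` is not yet measured and differs from compound 3 by one change: methyl in place of hydrogen on an amide-type nitrogen in a ring. Among the compounds with values here, no pair of measured compounds differs by this change alone, so the direction cannot be read from the measured pairs. Because compound 3 gives > 40 mg/kg, compound 4 may again end at a limit rather than a number. The step of an at least 1.3-fold lower number from compound 3 to compound 4 (0.12 log units; that floor lies within the scatter) is expected to be small, within the scatter or a modest move toward smaller doses. Compound 4 is estimated at 30 mg/kg, within a range from 8 mg/kg to 120 mg/kg.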

Compound 4, minimum effective dose: > 40 mg/kg
Compound 4 gave a limit, no number (the forecaster's own chance of this, stated with the estimate: 50%); middle value at least 1.3-fold (0.12 log units) away from the limit.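

Compound 3 and compound 4 both end at a limit of the assay, not a number, so the step between them cannot be read, and the effect of methyl on this amide-type nitrogen stays hidden because both values sit at the same limit: the limit of > 40 mg/kg in this assay, at which 2 of the 4 values shown sit.

Going by these compounds alone, what the result does add is a first readable comparison among compounds that carry this methyl. In this assay, 4-fluorophenyl in place of 3-fluorophenyl gives an at least 4.0-fold higher number from compound 2 to compound 4 (0.60 log units; beyond the scatter), so with the methyl present the place of the fluorine on the phenyl ring matters.

From the compounds shown here alone, the size of the methyl step itself remains open, and reading it would take a pair with numbers on both sides. Also open, going by these compounds, is whether an ethyl group or a longer chain ending in an amine on this nitrogen would bring a 4-fluorophenyl compound to a readable dose.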